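Dropping a methoxy from a diamino-quinoxaline cytotoxin

This account rests on a few compounds, and the source may have more. Where it says the series, first, only, none or still open, it means among the compounds named here.

Measured compounds:
compound 1, `COc1ccc(CNc2nc3cc(N)cc(N)c3nc2-c2ccccc2)cc1OC` – < 100000 nM
compound 2, `COc1cc(CNc2nc3cc(N)cc(N)c3nc2-c2ccccc2)cc(OC)c1OC` – 31600 nM

The shared core carries a benzylamine whose aromatic ring differs in its methoxy count. In a functional assay on OVCAR-8 cells (Homo sapiens) for inhibition, read by sulforhodamine B assay, with a stated time of 48 h (a higher number here means that more compound is tolerated, a lower number that less compound is tolerated), compound 1 gives only a limit, < 100000 nM, and not a number. Compound 2 gives 31600 nM in this assay. The change that separates them is methoxy in place of hydrogen on an aromatic carbon, and the resulting step, a step that the limit leaves unreadable from compound 1 to compound 2, cannot be sized because the limit of < 100000 nM in this assay, at which 1 of the 2 values shown sits, hides where compound 1 truly sits.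

Compound 3, `COc1ccc(CNc2nc3cc(N)cc(N)c3nc2-c2ccccc2)cc1`, is reached from compound 1 by hydrogen in place of methoxy on an aromatic carbon, so that the 3,4-dimethoxyphenyl becomes a 4-methoxyphenyl. For the measured compounds named here, no measured step bears on this change with a readable size, and compound 1 itself stands only as a limit. With that thin basis, compound 3 is expected to land in the same broad region as the measured pair, with a step that the limit leaves unreadable from compound 1 to compound 3 treated as no step beyond the scatter, though a limit may again be all that is seen. The estimate for compound 3 is 40000 nM, within 10000 nM to 100000 nM.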

Compound 3, concentration lethal to 50% of the cells: < 100000 nM
Compound 3 was reported as a limit; the forecaster's own chance of this, stated with the estimate: 35%; the middle value lies beyond the limit too.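

Compound 1 and compound 3 each stand only as a limit in this assay, not as a number, so no step between them can be read: the limit of < 100000 nM in this assay, at which 2 of the 3 values shown sit.

The compounds shown leave open where compound 1 and compound 3 truly sit, and so whether going from the 3,4-dimethoxyphenyl to the 4-methoxyphenyl changes the lethal concentration at all.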